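From 4-methylphenyl to 3-methylphenyl: compound 2 to compound 3

This account rests on a few compounds, and the source may have more. Where it says the series, first, only, none or still open, it means among the compounds named here.

Measured so far in an ADME assay on HUVEC cells (Homo sapiens) for cytotoxicity, read by MTT assay, with a stated time of 72 h; a lower number here means a stronger inhibitor, a higher number a weaker inhibitor:
Compound 1 `CCn1ccnc1-c1cc(OC)c(OC)c(OC)c1`: "not determined" (no result reported)
Compound 2 `COc1cc(-c2nccn2-c2ccc(C)cc2)cc(OC)c1OC`: > 100000 nM

Within the data shown here, compound 1 gives no result in this assay, so the series has no measured step between compounds. Compound 2 reads > 100000 nM, which is a limit of the assay and not a number. Its position is therefore known only as a limit, and no exact value is available for comparison.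

Compound 3 `COc1cc(-c2nccn2-c2cccc(C)c2)cc(OC)c1OC` has 3-methylphenyl in place of 4-methylphenyl on an aromatic nitrogen, next to the ring atom that bears a large group (3-methylphenyl in place of 4-methylphenyl on an aromatic nitrogen). The two compounds have the same atoms, joined differently.

Among the measured compounds shown here, with no measured step to serve as a guide, the expectation rests on compound 2 alone, with its limit of > 100000 nM. No change beyond the usual scatter is expected in this assay, in either direction, and another report of a limit is the likeliest outcome. The estimated step of a number no higher from compound 2 to compound 3 (the limit leaves the size open) is expected to stay within the scatter. For compound 3 the estimated value is 100000 nM, with an expected range of 40000 nM to 200000 nM.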

Compound 3, half-maximal inhibitory concentration: > 100000 nM
Compound 3: a limit, no number; the forecaster's own chance of this, stated with the estimate: 75%; the middle value sits exactly at the limit.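

In this assay compound 3 gives > 100000 nM, a limit of the assay and not a number. Compound 2 also reads as a limit, so no step can be read between compound 2 and compound 3. The compounds shown leave open whether any group on the aromatic nitrogen gives an exact value in this assay.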